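Adding a Methyl to the Side Chain of Compound 3

The source may report more compounds than this note shows. Statements on the series, on what has been measured and on what is new or still open speak of the compounds shown alone.

Measured in an ADME assay on L1210 cells (Mus musculus) for cytotoxicity, with a stated time of 48 h (on this read-out higher numbers stand for weaker inhibition and lower numbers for stronger inhibition), so far:
- compound 1 `CC1=CCC[C@](C)(CC/C(C)=C/CC2=C(O)C(=O)C=C(N[C@H](C(=O)O)[C@@H](C)O)C2=O)[C@@H]1C` gives > 10 ug/mL as a limit
- compound 2 `C=C1[C@H](C)CCC[C@]1(C)CC/C(C)=C/CC1=C(O)C(=O)C=C(N[C@@H](C(=O)O)[C@H](C)O)C1=O` gives 4.6 ug/mL as a number
- compound 3 `CC1=CCC[C@](C)(CC/C(C)=C/CC2=C(O)C(=O)C=C(N[C@H](CO)C(=O)O)C2=O)[C@@H]1C` gives > 10 ug/mL as a limit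

Compound 3 has no number, only a limit, and it stands at the limit of > 10 ug/mL in this assay, at which 2 of the 3 values shown sit, in the series. The change to compound 4 `CC1=CCC[C@](C)(CC/C(C)=C/CC2=C(O)C(=O)C=C(N[C@@H](C(=O)O)[C@H](C)O)C2=O)[C@@H]1C` is methyl in place of hydrogen on a saturated chain carbon bound to an oxygen on a saturated carbon and a saturated chain carbon and turns hydroxymethyl into 1-hydroxyethyl. Within the data shown here, the one measured step on this group is a step that the two limits leave unreadable from compound 1 to compound 3 and it offers no size to carry over. Among the measured compounds shown here, compound 2 carries the 1-carboxy-2-hydroxypropyl group on a different core and reads 4.6 ug/mL in this assay as the only number available. A modest move toward stronger inhibition is therefore expected, though with little confidence. The expected change is an at least 1.2-fold lower number from compound 3 to compound 4 (0.09 log units; that floor lies within the scatter) and remains a rough estimate. Compound 4 is estimated at 8 ug/mL in this assay with an expected range from 3 ug/mL to 20 ug/mL and a real chance of another limit.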

Compound 4, half-maximal inhibitory concentration: > 10 ug/mL
Compound 4: only a limit was reported; the forecaster's own chance of this, stated with the estimate: 50%; middle value at least 1.2-fold (0.09 log units) from the limit.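

In this assay compound 4 gives > 10 ug/mL, which is a limit and not a number, and the steps linking it to compound 1 and compound 3 cannot be read, so the methyl that turns hydroxymethyl into 1-hydroxyethyl gets no size: the limit of > 10 ug/mL in this assay, at which 3 of the 4 values shown sit. The change of configuration relative to compound 1 likewise brings no number onto the scale: the fact that compounds 1 and 4 differ only in the configuration as drawn. Among these compounds, the one step that can be read is an at least 2.1-fold higher number from compound 2 to compound 4 (0.33 log units; beyond the scatter), with the 1-carboxy-2-hydroxypropyl group the same in both and only the group holding the six-membered carbon ring exchanged.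

As far as these compounds go, whether the methyl changes anything that this limit conceals stays open, as does the effect of the configuration when the ring group is that of compound 2. The compounds shown also do not tell how an amine in place of the hydroxyl of the 1-hydroxyethyl group, or a longer chain there, would read.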